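This account rests on a few compounds, and the source may have more. Where it says the series, first, only, none or still open, it means among the compounds named here.

Compound 1 `CCc1cc(S(=O)(=O)N2C[C@H](c3ccccc3)NC2=O)ccc1NC(=O)OC(C)C`: 60 nM
Compound 2 `CCc1cc(S(=O)(=O)N2C[C@H](c3ccccc3)NC2=O)ccc1NC(=O)NC1CCCCC1`: 300 nM
Compound 3 `CC1[C@H](c2ccccc2)NC(=O)N1S(=O)(=O)c1ccc(NC(=O)c2ccc([N+](=O)[O-])cc2)c(Cl)c1`: > 10000 nM

All three were tested in a functional assay on HCT-116 cells (Homo sapiens) for cytotoxicity, read by MTT assay; a lower number here means a stronger inhibitor, a higher number a weaker inhibitor. Compound 3 sits at the limit of this assay rather than at a number (the limit of > 10000 nM in this assay, at which 1 of the 3 values shown sits). Of the two numbers, compound 2 stands highest; its nearest neighbour is compound 1, separated by the step of a 5.0-fold higher number from compound 1 to compound 2 (0.70 log units; beyond the scatter).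

Compound 4 `CCCOC(=O)Nc1ccc(S(=O)(=O)N2C[C@H](c3ccccc3)NC2=O)cc1CC` is not yet measured. It differs from compound 2 by propoxy in place of cyclohexylamino on a carbonyl carbon. Within the data shown here, the one measured step that bears on this is a 5.0-fold higher number from compound 1 to compound 2 (0.70 log units; beyond the scatter), which replaced an alkoxy group on that carbonyl carbon with cyclohexylamino; the change to compound 4 reverses it, restoring an alkoxy group, now propoxy. A downward step of similar size is therefore expected, a 4.3-fold lower number from compound 2 to compound 4 (0.63 log units; beyond the scatter). Compound 4 is estimated at 70 nM, between 25 nM and 200 nM.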

Compound 4, half-maximal inhibitory concentration: 60 nM
The estimate for compound 4 lay 1.2-fold (0.07 log units) above the measured number, within the range that was stated.
By their numbers in this assay, from the lowest: compounds 1 and 4 (each within the scatter of the next); then compound 2. At a limit, above all of these: compound 3.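

Propoxy in place of cyclohexylamino on the carbonyl carbon gives a 5.0-fold lower number from compound 2 to compound 4 (0.70 log units; beyond the scatter) in this assay, so the gap between cyclohexylamino and an alkoxy group now holds for two alkoxy groups, not only for isopropoxy. Propyl in place of isopropyl on the oxygen gives no change at the digits printed from compound 1 to compound 4 (within the scatter), so these two chains cannot be told apart here. No measurement shown gives a reason for either step.

Left open is how a longer chain such as butoxy would fare on this carbonyl carbon. A small amino group such as methylamino would help show whether the ring or the nitrogen of cyclohexylamino goes with the higher number.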